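Shared core, three limits, and an isobutyl amide

The source may report more compounds than this note shows. Statements on the series, on what has been measured and on what is new or still open speak of the compounds shown alone.

Compound 1 `C=CC1=C(C(=O)NCC(C)C)C(c2ccc(F)cc2)OC1` in a functional assay on QGY7701 cells (Homo sapiens) for cytotoxicity, read by MTT assay, with a stated time of 24 h (a lower number here means a stronger inhibitor, a higher number a weaker inhibitor), gives > 100000 nM, a limit of the assay.
Compound 2 `C=CC1=C(C(=O)Nc2ccc(OCC)cc2)C(c2ccc(OC)cc2)OC1` in this assay gives > 100000 nM, also a limit.
Compound 3 `C=CC1=C(C(=O)NCCCCC)C(c2ccc(OC)cc2)OC1` in this assay gives > 100000 nM, again a limit.

Compound 3 therefore stands only at a limit, as do the two other compounds, as shown by the limit of > 100000 nM in this assay, at which 3 of the 3 values shown sit. For the measured compounds named here, the single step between measured compounds, a step that the two limits leave unreadable from compound 2 to compound 3, cannot be read. Compound 4 `C=CC1=C(C(=O)NCC(C)C)C(c2ccc(OC)cc2)OC1` differs from compound 3 by isopropyl in place of butyl on a saturated chain carbon bound to an amide-type nitrogen. No readable measured step bears on this change; compound 1 carries the same isobutyl amide with a different aryl group and also sits at the limit. Compound 4 is therefore expected to stay at the limit, so the expected step that the limit leaves unreadable from compound 3 to compound 4 is none beyond the scatter. Compound 4 is estimated at 150000 nM, between 40000 nM and 1000000 nM.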

Compound 4, half-maximal inhibitory concentration: > 100000 nM
Compound 4: a limit, no number; the forecaster's own chance of this, stated with the estimate: 85%; the middle value lies beyond the limit too.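

For the compounds shown here, compound 1, compound 2, compound 3 and compound 4 all sit at a limit, so no step among them can be read: the limit of > 100000 nM in this assay, at which 4 of the 4 values shown sit.
The compounds shown leave open whether, in this assay, changing the amide substituent or the aryl group shifts cytotoxicity at all.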